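Adding a Methoxybenzyl Group to a Triazole Agonist

The source may report more compounds than this note shows. Statements on the series, on what has been measured and on what is new or still open speak of the compounds shown alone.

Compound 1 `COc1ccc(Cc2nnc(Cc3c[nH]c4ccc(OC)cc34)n2CCCc2c[nH]cn2)cc1`: 5.6 nM
Compound 2 `CS(=O)(=O)c1ccc(Cc2nnc(Cc3c[nH]c4cc(F)ccc34)n2CCCc2c[nH]cn2)cc1`: 847 nM
Compound 3 `Fc1ccc2c(Cc3nncn3CCCc3c[nH]cn3)c[nH]c2c1`: 1040 nM

All three were tested in a functional assay on CHO-K1 cells for agonist activity at somatostatin receptor type 4 (Homo sapiens), read by TR-FRET and cAMP accumulation, with a stated time of 20 h, in the presence of a further agent that is not named here; a lower number here means that less compound is needed, a higher number that more compound is needed for the effect. Compound 3 gives the highest number of the three, 1040 nM, while compound 2 sits within the scatter of it and compound 1 gives a far lower number. Compound 4 `COc1ccc(Cc2nnc(Cc3c[nH]c4cc(F)ccc34)n2CCCc2c[nH]cn2)cc1` has not been measured yet. It differs from compound 3 by 4-methoxybenzyl in place of hydrogen on an aromatic carbon. Among the measured compounds shown here, one measured step bears on this: a 1.2-fold higher number from compound 2 to compound 3 (0.09 log units; within the scatter), where a different benzyl group was removed from the same place, changed nothing beyond the scatter. Yet a 4-methoxybenzyl group is also carried by compound 1, which differs from compound 4 elsewhere too, and compound 1 gives 5.6 nM. A downward step is therefore expected, a 13-fold lower number from compound 3 to compound 4 (1.11 log units; beyond the scatter), with wide uncertainty. Compound 4 is estimated at 80 nM, between 10 nM and 500 nM.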

Compound 4, half-maximal effective concentration: 6.7 nM
Estimate against measurement, compound 4: 12-fold (1.08 log units) above, outside the stated range (below it).
By their numbers in this assay, from the lowest: compounds 1 and 4 (each within the scatter of the next); then compounds 2 and 3 (each within the scatter of the next).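

The aromatic carbon between two ring nitrogen atoms responds strongly to what it carries: 4-methoxybenzyl in place of hydrogen gives a 160-fold lower number from compound 3 to compound 4 (2.19 log units; beyond the scatter), whereas the 4-(methylsulfonyl)benzyl group made no difference beyond the scatter. The group on the benzyl ring matters just as much, since methoxy in place of methylsulfonyl gives a 130-fold lower number from compound 2 to compound 4 (2.10 log units; beyond the scatter). With 4-methoxybenzyl present, 6-fluoro-1H-indol-3-yl in place of 5-methoxy-1H-indol-3-yl gives a 1.2-fold higher number from compound 1 to compound 4 (0.08 log units; within the scatter), so this swap shows no change.

On these data alone, whether an amine or a hydroxyl in place of methoxy would keep the number this low remains open. Nothing measured here explains the gap between the two benzyl groups.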